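The compounds below may be only part of what the source reports. "The series", "measured", "known", "first", "only" and "open" are said of these compounds alone.

Measured compounds:
- Compound 1, `CC(C)(C)OC(=O)N(Cc1ccco1)C(=O)c1ccc(CN2Cc3ccccc3S2(=O)=O)cc1`, in a functional assay on RAW264.7 cells (Mus musculus) for inhibition (a higher number here means a weaker inhibitor, a lower number a stronger inhibitor), compound 1 gives 10600 nM.
- Compound 2, `O=C(c1ccc(Cn2c(=O)c3ccccc3[s+]2[O-])cc1)N1CCCCC1`, compound 2 gives 49000 nM.
- Compound 3, `CC(C)(C)OC(=O)N(Cc1ccco1)C(=O)c1ccc(Cn2c(=O)c3ccccc3[s+]2[O-])cc1`, compound 3 gives 68000 nM.

Compound 3 has the highest of the three numbers, which makes it the weakest inhibitor among them, though its gap to compound 2 is within the scatter, so those two cannot be ordered. Within the data shown here, only the step to compound 1 is clear: a 6.4-fold higher number from compound 1 to compound 3 (0.81 log units; beyond the scatter).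

Compound 4, `O=C(NCc1ccco1)c1ccc(Cn2c(=O)c3ccccc3[s+]2[O-])cc1`, is made from compound 3 by one change: hydrogen in place of tert-butoxycarbonyl on an amide-type nitrogen. Among the measured compounds shown here, none of the measured steps touches this position. For the measured compounds named here, the one measured step, from compound 1 to compound 3, changes the ring system at the other end of the molecule, so it says nothing about removing the tert-butoxycarbonyl group. Compound 2 and compound 3 differ at the amide nitrogen in a different way and sit within the scatter of each other, which hints that changes at this nitrogen may matter little. Going by the values given here, with no direct precedent, the expectation is a step of no clear direction, a 1.4-fold lower number from compound 3 to compound 4 (0.13 log units; within the scatter), within the scatter. Compound 4 is therefore estimated at 50000 nM, with a range from 15000 nM to 160000 nM.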

Compound 4, half-maximal inhibitory concentration: 23300 nM
Estimate against measurement, compound 4: 2.1-fold (0.33 log units) above; the range from low to high includes it.
By their numbers in this assay, from the lowest: compound 1; then compound 4; then compounds 2 and 3 (each within the scatter of the next).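

In this assay, putting hydrogen in place of tert-butoxycarbonyl on the amide-type nitrogen gives a 2.9-fold lower number from compound 3 to compound 4 (0.47 log units; beyond the scatter), so this position does respond to change, and the group that leaves was costing some inhibition. Replacing piperidin-1-yl on the carbonyl carbon with ((furan-2-yl)methyl)amino gives a 2.1-fold lower number from compound 2 to compound 4 (0.32 log units; beyond the scatter), a difference that compound 2 and compound 3, which sit within the scatter of each other, did not reveal. No measurement available here explains why either step goes in this direction.

A group smaller than tert-butoxycarbonyl on this nitrogen, such as methyl or acetyl, would show whether the hydrogen itself matters or only the loss of the larger group. Also open, on these data alone, is how much the (furan-2-yl)methyl group contributes, which a benzyl group or a butyl chain in its place would test.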